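The source may report more compounds than this note shows. Statements on the series, on what has been measured and on what is new or still open speak of the compounds shown alone.

Measured so far in a functional assay on the whole organism for antagonist activity, with Mus musculus as the target; on this read-out higher numbers stand for an effect only at larger amounts of compound and lower numbers for an effect already at smaller amounts:
compound 1, `CN(C)C(=O)N(C)CC#CCN1CCCC1`, gives 6.6 mg/kg.
compound 2, `CN(C)C(=O)N(C)CC#CCn1ccnc1`, gives 11.8 mg/kg.
compound 3, `Cn1ccn(CC#CCN2CCCC2)c1=O`, gives > 10 mg/kg, which is a limit of the assay rather than a number.

Compound 1 and compound 2 share one core and differ only by 1H-imidazol-1-yl in place of pyrrolidin-1-yl on a saturated chain carbon bound to a triple-bonded carbon. That change gave a 1.8-fold higher number from compound 1 to compound 2 (0.25 log units; within the scatter). Compound 3 carries a different core; the difference between the two cores is not broken down here. Compound 4, `Cn1ccn(CC#CCn2ccnc2)c1=O`, is not yet measured and stands to compound 3 exactly as compound 2 stands to compound 1: the same change, (1H-imidazol-1-yl in place of pyrrolidin-1-yl on a saturated chain carbon bound to a triple-bonded carbon). A similarly small step is expected, a step that the limit leaves unreadable from compound 3 to compound 4, because the measured pair showed a 1.8-fold higher number from compound 1 to compound 2 (0.25 log units; within the scatter). Compound 3 sits at the limit of > 10 mg/kg in this assay, at which 1 of the 3 values shown sits, so compound 4 is expected to give only a limit as well. The estimate for compound 4 in this assay is 20 mg/kg, ranging from 10 mg/kg to 50 mg/kg.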

Compound 4, dose for half-maximal effect: > 100 mg/kg
Compound 4 gave a limit, no number (the forecaster's own chance of this, stated with the estimate: 80%); middle value at least 5.0-fold (0.69 log units) away from the limit.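

Compound 3 and compound 4 each gave only a limit in this assay, not a number, so the step between them cannot be read. The compounds shown leave open how far 1H-imidazol-1-yl in place of pyrrolidin-1-yl moves the dose on this core.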